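Dichlorophenyl Replacing Fluorophenyl on a Shared Core

The source may report more compounds than this note shows. Statements on the series, on what has been measured and on what is new or still open speak of the compounds shown alone.

Compound 1 `CN(CC1=CC[C@H]2C[C@@H]1C2(C)C)Cc1ccc(F)cc1` and compound 2 `CN(CC1=CC[C@H]2C[C@@H]1C2(C)C)Cc1ccc(-c2ccccc2)cc1` share their core with compound 3 `CN(CC1=CC[C@H]2C[C@@H]1C2(C)C)Cc1ccc(-c2ccccc2F)cc1`. In an assay on HEK293 cells for displacement of a labelled ligand from C-X-C chemokine receptor type 3 (Homo sapiens) (a lower number here means a stronger inhibitor, a higher number a weaker inhibitor), compound 1 gives 6310 nM. Compound 2 gives 3160 nM in this assay, a change of a 2.0-fold lower number from compound 1 to compound 2 (0.30 log units; within the scatter). For compound 3 this assay returns only a limit, > 316 nM, this being (the limit of > 316 nM in this assay, at which 1 of the 3 values shown sits). The steps a step that the limit leaves unreadable from compound 1 to compound 3 and a step that the limit leaves unreadable from compound 2 to compound 3 therefore cannot be sized. Compound 4 `CN(CC1=CC[C@H]2C[C@@H]1C2(C)C)Cc1ccc(-c2cc(Cl)cc(Cl)c2)cc1` differs from compound 3 by 3,5-dichlorophenyl in place of 2-fluorophenyl on an aromatic carbon. No measured step bears on this change, and the value of compound 3 is itself only a limit, so neither size nor direction can be read from the numbers shown. Compound 4 is expected to give about 2500 nM in this assay, between 500 nM and 10000 nM. The step from compound 3 to compound 4 that this estimate means is a step that the limit leaves unreadable from compound 3 to compound 4.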

Compound 4, inhibition constant: > 316 nM
Compound 4 ended at the assay's limit; the forecaster's own chance of this, stated with the estimate: 40%; the middle value is on the limit's open side.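

In this assay, within the data shown here, compound 4 returns only a limit, so no step to compound 4 from compound 1, compound 2 or compound 3 can be read: the limit of > 316 nM in this assay, at which 2 of the 4 values shown sit. The compounds shown leave open whether 3,5-dichlorophenyl or 2-fluorophenyl gives the lower number, and how either compares with the unsubstituted phenyl of compound 2.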